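The source may report more compounds than this note shows. Statements on the series, on what has been measured and on what is new or still open speak of the compounds shown alone.

Compound 1 `O=C(CCc1cccc2c1B(O)OC2)NCc1ccccc1` and compound 2 `CC(C)c1cccc(NC(=O)CCc2cccc3c2B(O)OC3)c1` share one core and differ only in the group carried by the amide. In a functional assay on SK-OV-3 cells (Homo sapiens) for antiproliferative activity, read by MTT assay, with a stated time of 72 h (a higher number here means a weaker inhibitor, a lower number a stronger inhibitor), compound 1 reaches only a limit of the assay, > 100000 nM. In this assay, for the measured compounds named here, compound 2 gives 510 nM, the sole number among the two values shown, the other sitting at the limit of > 100000 nM in this assay, at which 1 of the 2 values shown sits. Compound 3 `O=C(CCc1cccc2c1B(O)OC2)Nc1cccc(-c2ccc(C(F)(F)F)cc2)c1` has not yet been measured. It differs from compound 2 by 4-(trifluoromethyl)phenyl in place of isopropyl on an aromatic carbon. Going by the values given here, no measured pair shows a change of this kind, so the step is expected to stay within the usual scatter, at a 1.1-fold lower number from compound 2 to compound 3 (0.05 log units; within the scatter). Compound 3 is therefore estimated at 450 nM, between 120 nM and 2000 nM.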

Compound 3, half-maximal inhibitory concentration: 500 nM
Compound 3: middle estimate off by 1.1-fold (0.05 log units), on the low side; low and high end bracket the measured number.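

In this assay the swap of isopropyl for 4-(trifluoromethyl)phenyl, on an aromatic carbon meta to a large group, gives a 1.0-fold lower number from compound 2 to compound 3 (0.01 log units; within the scatter) and so leaves the two compounds reading alike. This position therefore accepts a much larger group that brings its own aromatic ring, with no measurable loss of antiproliferative activity. Going by these compounds, whether an amine or a carboxylic acid at this position would read the same remains open, as does the outcome with a longer alkyl chain. Nothing given here accounts for why these two groups read alike.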